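The source may hold more compounds than are shown below. What is called first, only, known or untested is meant among the compounds shown, and "the series" means these compounds.

In a functional assay on MCF7 cells (Homo sapiens) for cytotoxicity, read by MTT assay, with a stated time of 48 h (on this read-out lower numbers stand for stronger inhibition and higher numbers for weaker inhibition), compound 3 `Oc1ccc(Nc2nc(-c3cccc(F)c3)nc3ccc(F)cc23)cc1` reaches only the limit of the assay, > 50000 nM, so no true number is known for it. Compound 1 `Fc1cccc(-c2nc(Nc3ccccc3F)c3cc(F)ccc3n2)c1` gives > 50000 nM, also a limit rather than a number. Compound 2 `Fc1cccc(-c2nc(Nc3cccc(Br)c3)c3cc(F)ccc3n2)c1` likewise gives > 50000 nM, again only a limit. Because the limit of > 50000 nM in this assay, at which 3 of the 3 values shown sit, holds every value, the steps a step that the two limits leave unreadable from compound 1 to compound 2, a step that the two limits leave unreadable from compound 1 to compound 3 and a step that the two limits leave unreadable from compound 2 to compound 3 remain unreadable in size. Compound 4 `Nc1cccc(Nc2nc(-c3cccc(F)c3)nc3ccc(F)cc23)c1` arises from compound 3 by 3-aminophenyl in place of 4-hydroxyphenyl on a nitrogen on an aromatic ring. For the measured compounds named here, no measured step bears on this change, so no shift beyond the usual scatter can be expected in either direction. Compound 4 is therefore estimated at 70000 nM, within 20000 nM to 300000 nM, and most probably as a limit once more. The expected step that the limit leaves unreadable from compound 3 to compound 4 is accordingly close to none.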

Compound 4, half-maximal inhibitory concentration: > 50000 nM
Compound 4: only a limit was reported; the forecaster's own chance of this, stated with the estimate: 85%; the middle value does not contradict the limit.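

For the compounds shown here, no step from compound 1, compound 2 or compound 3 to compound 4 can be read, because each value is a limit and not a number: the limit of > 50000 nM in this assay, at which 4 of the 4 values shown sit. The compounds shown leave open whether any of these groups on the shared core changes the cytotoxicity, and by how much.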